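One methoxy removed from a compound at the limit

The source may hold more compounds than are shown below. What is called first, only, known or untested is meant among the compounds shown, and "the series" means these compounds.

Measured in a functional assay on RAW264.7 cells (Mus musculus) for inhibition, with stated times of 2 h and 24 h; a higher number here means a weaker inhibitor, a lower number a stronger inhibitor:
- Compound 1 `COc1cc(OC)cc([C@@H]2C(O)c3cc(OC)cc(OC)c3[C@H]2c2ccccc2)c1`: 3380 nM
- Compound 2 `COc1cc(OC)cc([C@@H]2C(SCc3ccccc3)c3cc(OC)cc(OC)c3[C@H]2c2ccccc2)c1`: > 200000 nM (a limit)
- Compound 3 `COc1ccc(C(O)C2c3cc(OC)cc(OC)c3[C@@H](c3ccc(OC)cc3)[C@@H]2c2cc(OC)cc(OC)c2)cc1`: > 200000 nM (a limit)

Compound 3 stands at the limit of > 200000 nM in this assay, at which 2 of the 3 values shown sit, so it has a limit and no number. Compound 4 `COc1ccc(C(O)C2c3cc(OC)cc(OC)c3[C@@H](c3ccccc3)[C@@H]2c2cc(OC)cc(OC)c2)cc1` differs from it by hydrogen in place of methoxy on an aromatic carbon, with hydrogen in place of methoxy on an aromatic carbon, para to a large group. Among the measured compounds shown here, the only measured step is an at least 59-fold higher number from compound 1 to compound 2 (1.77 log units; beyond the scatter). That step is large, but it lies on a saturated ring carbon and does not test this change. No step beyond the scatter is therefore expected in this assay, and the expected step is an at least 1.3-fold lower number from compound 3 to compound 4 (0.12 log units; that floor lies within the scatter). Compound 4 is estimated at 150000 nM, with an expected range of 40000 nM to 400000 nM.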

Compound 4, half-maximal inhibitory concentration: 16500 nM
The estimate for compound 4 lay 9.1-fold (0.96 log units) above the measured number, and the stated range ends above it.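

In this assay, removing the methoxy on the aromatic carbon, para to a large group, matters a great deal: 4-methoxyphenyl to phenyl gives an at least 12-fold lower number from compound 3 to compound 4 (1.08 log units; beyond the scatter). With that phenyl in place, hydroxy(4-methoxyphenyl)methyl on the saturated ring carbon does better than benzylsulfanyl, with an at least 12-fold lower number from compound 2 to compound 4 (1.08 log units; beyond the scatter). It still falls short of plain hydroxy, with a 4.9-fold higher number from compound 1 to compound 4 (0.69 log units; beyond the scatter).

From the compounds shown here alone, compound 3 has only a limit, so the full size of the methoxy step stays open: the limit of > 200000 nM in this assay, at which 2 of the 4 values shown sit. Going by these compounds, whether fluorine or an amine at that aromatic carbon would behave like hydrogen also remains open.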